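The source may report more compounds than this note shows. Statements on the series, on what has been measured and on what is new or still open speak of the compounds shown alone.

Series notes, sulfonamide arm on the shared core.

Compound 1 `COc1cccc(S(=O)(=O)Nc2ccc3oc(-c4ccccc4)nc3c2)c1` in an assay on cells for inhibition of HSP60/HSP10 (Homo sapiens), with a stated time of 60 min (a higher number here means a weaker inhibitor, a lower number a stronger inhibitor), gives > 100000 nM, which is a limit of the assay and not a number. Compound 2 `O=S(=O)(Nc1ccc2oc(-c3ccccc3)nc2c1)c1ccc(Cl)cc1` gives > 100000 nM in this assay, again a limit. The change from compound 1 to compound 2 is 4-chlorophenyl in place of 3-methoxyphenyl on a sulfonyl sulfur, and its step that the two limits leave unreadable from compound 1 to compound 2 cannot be read. On the numbers shown, compound 2 stands only at a limit, and the same holds for the other value: the limit of > 100000 nM in this assay, at which 2 of the 2 values shown sit.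

Compound 3 `O=S(=O)(Nc1ccc2oc(-c3ccccc3)nc2c1)c1ccc(C(F)(F)F)cc1` differs from compound 2 by trifluoromethyl in place of chloro on an aromatic carbon. Among the measured compounds shown here, the one measured step that bears on it, a step that the two limits leave unreadable from compound 1 to compound 2, has no readable size, so no direction beyond the scatter is expected in this assay. Compound 3 is therefore expected to sit at or near the limit as well, at an estimated 150000 nM with a range of 30000 nM to 1000000 nM. The expected step is a step that the limit leaves unreadable from compound 2 to compound 3.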

Compound 3, half-maximal inhibitory concentration: > 100000 nM
Compound 3: a limit, no number; the forecaster's own chance of this, stated with the estimate: 85%; the middle value is on the limit's open side.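

Compound 3 also gives only a limit and not a number in this assay, so the step from compound 2 to compound 3 cannot be read. Whether any sulfonyl substituent on the shared core gives a measurable value stays open: the limit of > 100000 nM in this assay, at which 3 of the 3 values shown sit.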